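A few compounds are considered here, and "the series" means these few. Any claim that something is new, unique, unknown or untested is made for them only; others in the source may bear on it.

Working notes on the series. Compound 1 `O=C1Nc2ccccc2/C1=C1/Oc2ccccc2C1=O` and compound 2 `O=C1NC(=S)N/C1=C1\C(=O)Nc2ccccc21` share a core; both were run in a functional assay on U-373MG ATCC cells (Homo sapiens) for antiproliferative activity, read by MTT assay, with a stated time of 72 h; on this read-out higher numbers stand for weaker inhibition and lower numbers for stronger inhibition. In this assay compound 1 gives 27700 nM, and in this assay compound 2 gives 51900 nM. Of the two numbers compound 2 stands at the top, but its gap to compound 1 is within the usual scatter of this read-out, so the two values cannot be told apart and neither compound can be called the weaker.

The next compound, compound 3 `O=C1NC(=S)N/C1=C1\C(=O)Nc2c(Br)cccc21`, departs from compound 2 in a single place: bromo in place of hydrogen on an aromatic carbon. Within the data shown here, no step between measured compounds is available, so there is no read of how a change on the six-membered aromatic ring moves the number in this assay. With only the two values of compound 1 and compound 2 to draw on, and with the change adding one heavy atom, the expected step is small, not beyond the scatter, and without a fixed direction.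

On that basis compound 3 is estimated at 38000 nM in this assay, with a range of 12000 nM to 110000 nM. The estimated step of a 1.4-fold lower number from compound 2 to compound 3 (0.14 log units; within the scatter) is expected to lie within the scatter.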

Compound 3, half-maximal inhibitory concentration: 4700 nM
Compound 3: middle estimate off by 8.1-fold (0.91 log units), on the high side; measured number outside the range, below it.
By their numbers in this assay, from the lowest: compound 3; then compounds 1 and 2 (each within the scatter of the next).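

On the six-membered aromatic ring of carbon only, at the place ortho to a fused ring and meta to a fused ring, bromo in place of hydrogen gives an 11-fold lower number from compound 2 to compound 3 (1.04 log units; beyond the scatter) in this assay and gives the first read of this position. The position is therefore not silent on this read-out: a change of 1 heavy atom, a bromine, carries the number beyond the scatter, in the direction of stronger inhibition. No measurement at hand accounts for the size of this step, so it stands as an observation from a single pair.

As far as these compounds go, it remains open whether the drop is particular to bromo or would also follow from another group on the same aromatic carbon, such as chloro, methoxy, an amine or a carboxylic acid. From the compounds shown here alone, it is equally open whether bromo would move the number in the same direction and by a similar size on the other carbons of this ring, or on the core of compound 1.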